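A Methyl on the Furan Ring of Compound 3

A few compounds are considered here, and "the series" means these few. Any claim that something is new, unique, unknown or untested is made for them only; others in the source may bear on it.

Compound 1 `N#C/C(=C\c1c[nH]c2ccccc12)C(=O)c1c[nH]c2ccccc12`: 8300 nM
Compound 2 `COc1ccc(CNC(=O)/C(C#N)=C/c2ccc[nH]2)cc1`: > 50000 nM
Compound 3 `COc1ccc(CNC(=O)/C(C#N)=C/c2ccco2)cc1`: 31000 nM

In a functional assay on SW480 cells (Homo sapiens) for inhibition, read by MTT assay, with a stated time of 72 h (on this read-out higher numbers stand for weaker inhibition of growth and lower numbers for stronger inhibition of growth), compound 3 stands at the highest of the two real numbers, since compound 1 gives a number lower than compound 3 by a margin beyond the scatter. The value of compound 2 is a limit of the assay, not a number, as the limit of > 50000 nM in this assay, at which 1 of the 3 values shown sits, states. The only measured step between neighbouring structures, an at least 1.6-fold lower number from compound 2 to compound 3 (0.20 log units; that floor lies within the scatter), has a floor that lies within the scatter, so the shown numbers do not establish that swapping the five-membered ring changes growth inhibition.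

Compound 4 `COc1ccc(CNC(=O)/C(C#N)=C/c2ccc(C)o2)cc1` differs from compound 3 by methyl in place of hydrogen on an aromatic carbon. Within the data shown here, no measured step adds a methyl to an aromatic ring, so none bears directly on this change, and the one step that exists, from the pyrrole to the furan of compound 3, was itself within the scatter. Compound 4 is therefore expected to sit close to compound 3, with an expected step of no change at the digits printed from compound 3 to compound 4 (within the scatter), no change beyond the scatter. The estimate for compound 4 is 31000 nM, between 12000 nM and 80000 nM.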

Compound 4, concentration for 50% growth inhibition: 29000 nM
Compound 4: the middle estimate sits 1.1-fold (0.03 log units) above what was measured; the range from low to high includes it.
By their numbers in this assay, from the lowest: compound 1; then compounds 4 and 3 (each within the scatter of the next). At a limit, above all of these: compound 2.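

In this assay, among these compounds, the earlier compounds said nothing about the aromatic carbon next to the ring oxygen, and methyl in place of hydrogen there gives a 1.1-fold lower number from compound 3 to compound 4 (0.03 log units; within the scatter), so this position takes a methyl with no change that can be told from the scatter. Against the pyrrole, the step of an at least 1.7-fold lower number from compound 2 to compound 4 (0.23 log units; that floor lies within the scatter) is no firmer a reading than the one to the unsubstituted furan, so the swap of five-membered ring still shows no established change. Compound 2 stands at a limit of the assay, not a number: the limit of > 50000 nM in this assay, at which 1 of the 4 values shown sits.

From the compounds shown here alone, whether an ethyl, an amine or a carboxylic acid at this same position would shift the number remains open. So does whether a methyl on the pyrrole ring of compound 2 would behave as it does on the furan.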